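The source may hold more compounds than are shown below. What is called first, only, known or untested is meant among the compounds shown, and "the series" means these compounds.

Three compounds share one core and differ only in two aromatic rings at its ends. Compound 1 `Cc1ccc(-c2csc(NC(=O)COc3ccc(Cl)c(C)c3)n2)cc1` in a functional assay on MDA-MB-468 cells (Homo sapiens) for cytotoxicity, read by trypan blue exclusion, with a stated time of 48 h (a higher number here means a weaker inhibitor, a lower number a stronger inhibitor), gives 54700 nM, the highest of the three numbers, although its gaps to the other two are within the scatter. Compound 2 `Cc1cc(OCC(=O)Nc2nc(-c3ccc(Br)cc3)cs2)ccc1Cl` gives 51700 nM in this assay, and compound 3 `Cc1ccccc1OCC(=O)Nc1nc(-c2ccc(Br)cc2)cs1` gives 44500 nM. The step of a 1.1-fold lower number from compound 1 to compound 2 (0.02 log units; within the scatter) puts bromo in place of methyl on an aromatic carbon, and the step of a 1.2-fold lower number from compound 2 to compound 3 (0.07 log units; within the scatter) exchanges the ring on the oxygen on a saturated carbon; neither moves the number beyond the scatter. Compound 4 `Cc1ccc(OCC(=O)Nc2nc(-c3ccc(C)cc3)cs2)cc1` differs from compound 1 by 4-methylphenyl in place of 4-chloro-3-methylphenyl on an oxygen on a saturated carbon. Among the measured compounds shown here, this change sits at the same place as the one between compound 2 and compound 3, which is therefore the step that bears on it, and that step was within the scatter. Compound 4 is accordingly expected to show no step beyond the scatter, a change of a 1.1-fold lower number from compound 1 to compound 4 (0.04 log units; within the scatter). The value of compound 4 in this assay is estimated at 50000 nM, with a range from 25000 nM to 100000 nM.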

Compound 4, half-maximal inhibitory concentration: 37100 nM
The estimate for compound 4 lay 1.3-fold (0.13 log units) above the measured number; the range from low to high includes it.
By their numbers in this assay, from the lowest: compounds 4, 3, 2 and 1 (each within the scatter of the next).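

In this assay, the step of a 1.5-fold lower number from compound 1 to compound 4 (0.17 log units; within the scatter) shows that replacing 4-chloro-3-methylphenyl on the oxygen with 4-methylphenyl does not move the number beyond the scatter. Until now, a ring exchange at this place had been read only between compound 2 and compound 3, which both carry bromo on the other aromatic ring, whereas compound 1 and compound 4 both carry methyl there, so the same outcome now holds with either group. No measurement shown here offers a reason for these numbers.

All four compounds lie within the scatter of their neighbours in the ranking, so none of the changes shown marks a group that this assay responds to. As far as these compounds go, whether an amine or a carboxylic acid on the ring, or a longer chain in its place, would produce a step beyond the scatter remains open.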